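The source may report more compounds than this note shows. Statements on the series, on what has been measured and on what is new or still open speak of the compounds shown alone.

Measured so far:
- Compound 1 `Cc1ccc2oc(/C=C/[S+](C)[O-])cc(=O)c2c1`: 7000 nM
- Compound 2 `COc1cccc2oc(/C=C/[S+](C)[O-])cc(=O)c12`: > 10000 nM

Both compounds were tested in a functional assay on DLD-1 cells (Homo sapiens) for cytotoxicity, with a stated time of 48 h; on this read-out higher numbers stand for weaker inhibition and lower numbers for stronger inhibition. Among the compounds with values here, compound 1 gives 7000 nM, the only exact number available so far. Compound 2 gives > 10000 nM, which is a limit of the assay. Within the data shown here, compound 1 is therefore the single firm reference point, and no step between two measured compounds is available to guide a forecast.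

The compound still to be measured is compound 3 `CC(C)C(=O)Oc1ccc2oc(/C=C/[S+](C)[O-])cc(=O)c2c1`. It keeps the core of compound 1 but carries (isopropylcarbonyl)oxy in place of methyl on an aromatic carbon. Among the measured compounds shown here, the swap adds a larger group, but no measured pair shows what a change at this place does in this assay. No direction can be favoured, so the expectation is no shift beyond the scatter, starting from compound 1 at 7000 nM. The expected step is a 1.2-fold lower number from compound 1 to compound 3 (0.07 log units; within the scatter). For compound 3 the estimated value is 6000 nM, with an expected range from 2000 nM to 18000 nM.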

Compound 3, half-maximal inhibitory concentration: 9100 nM
Beside the measured number, compound 3's estimate is 1.5-fold (0.18 log units) below it, and the stated range covers the measured number.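

In this assay, within the data shown here, replacing methyl with (isopropylcarbonyl)oxy on this aromatic carbon gives a 1.3-fold higher number from compound 1 to compound 3 (0.11 log units; within the scatter), and this is the only measured change at this place. The larger group, which brings hydrogen-bond acceptors where methyl has none, therefore leaves two compounds that this read-out cannot tell apart, so this one swap at this place gives no measurable gain or loss in cytotoxicity. Both numbers also lie fairly close to the upper end of what the read-out reports as an exact value, which leaves limited room to size any weakening: the limit of > 10000 nM in this assay, at which 1 of the 3 values shown sits.

From the compounds shown here alone, with only methyl and (isopropylcarbonyl)oxy compared at this place, it stays open whether any group there can move the number beyond the scatter, in either direction. A hydroxyl, an amine or a carboxylic acid on the same aromatic carbon, or a longer chain in place of the isopropyl part, would show whether this place responds to other kinds of group or whether the result holds for substituents well beyond this pair.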